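The source may hold more compounds than are shown below. What is called first, only, known or untested is meant among the compounds shown, and "the series" means these compounds.

Measured in an assay on HeLa cells for displacement of a labelled ligand from 5-hydroxytryptamine receptor 6 (Homo sapiens); a higher number here means a weaker inhibitor, a lower number a stronger inhibitor:
- compound 1, `COc1cccc(S(=O)(=O)c2n[nH]c3ccc(N4CCN(C)CC4)cc23)c1`: 1.1 nM
- compound 2, `CN1CCN(c2cccc3c(S(=O)(=O)c4cccc5ccccc45)n[nH]c23)CC1`: 4.6 nM
- compound 3, `Cc1ccc(S(=O)(=O)c2n[nH]c3cccc(N4CCNCC4)c23)cc1`: 134 nM

Compound 1 holds the lowest number of the three in this assay. Compound 2 stands nearest to it, at a gap that lies beyond the usual scatter; compound 3 stands furthest, at a gap well beyond it. Compound 2 and compound 3 differ from compound 1 in more than one place each, so no single change can be read off from them.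

Compound 4, `CN1CCN(c2ccc3[nH]nc(S(=O)(=O)c4cccs4)c3c2)CC1`, differs from compound 1 by a single change: thiophen-2-yl in place of 3-methoxyphenyl on a sulfonyl sulfur. Among the measured compounds shown here, no measured pair carries this change, so the step can only be anticipated. Both groups join the sulfonyl sulfur through an aromatic ring and bring one hydrogen-bond acceptor; the ring that enters is the smaller of the two. The expected step is a 2.7-fold higher number from compound 1 to compound 4 (0.44 log units; beyond the scatter), a modest rise in the number that may not clear the scatter. Compound 4 is estimated at 3 nM, with a likely range from 0.8 nM to 12 nM.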

Compound 4, inhibition constant: 7.8 nM
The estimate for compound 4 lay 2.6-fold (0.41 log units) below the measured number; the measured number falls inside the stated range.
By their numbers in this assay, from the lowest: compound 1; then compounds 2 and 4 (each within the scatter of the next); then compound 3.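

In this assay, the first step read at this place, on a sulfonyl sulfur, is a 7.1-fold higher number from compound 1 to compound 4 (0.85 log units; beyond the scatter), so thiophen-2-yl does not match 3-methoxyphenyl here, and the gap lies beyond the usual scatter. Compound 4 still gives 7.8 nM, which shows that a five-membered aromatic ring with one hetero atom is accepted at this place, though a single change swaps the ring, adds the sulfur and removes the methoxy group, and this step cannot separate them. Nothing measured beyond these binding numbers bears on why the number rises.

On these data alone, whether a plain phenyl or a furan-2-yl on the sulfonyl sulfur would fall nearer compound 1 or compound 4 stays open. Also open, as far as these compounds go, is whether a saturated ring such as cyclohexyl is accepted at this place.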